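Switching the terminal aryl ether for a direct phenyl

The compounds below may be only part of what the source reports. "The series", "measured", "known", "first", "only" and "open" are said of these compounds alone.

Compound 1 `CC(Oc1ccc(Oc2ccc(F)cc2)cc1)C(=O)Cn1nnc(-c2ccccc2)n1` and compound 2 `CC(Oc1ccc(Oc2ccc(C(F)(F)F)cc2)cc1)C(=O)Cn1nnc(-c2ccccc2)n1` share one core and differ only in the group on the distal ring. In a physicochemical assay for lipophilicity, read by HPLC, tested at 5 mM (a lower number here means a more polar compound, a higher number a more lipophilic compound), compound 1 gives 5.3, and compound 2 gives 6.2. Within the data shown here, the step of a number 0.90 log units higher from compound 1 to compound 2 (beyond the scatter) is the only measured step in the set, and compound 2 stands highest of the two numbers in this assay. Compound 3 `CC(Oc1ccc(-c2ccccc2)cc1)C(=O)Cn1nnc(-c2ccccc2)n1` is not yet measured. Compound 3 differs from compound 2 by phenyl in place of 4-(trifluoromethyl)phenoxy on an aromatic carbon. Among the measured compounds shown here, the measured step bears on this only in part: the trifluoromethyl that is removed here is the group whose entry gave the rise from compound 1 to compound 2, but no measured pair shows the loss of the ether oxygen itself. The expected direction is downward, by a step of roughly a number 1.20 log units lower from compound 2 to compound 3 (beyond the scatter), on the strength of the measured step of a number 0.90 log units higher from compound 1 to compound 2 (beyond the scatter). For compound 3 the expected value in this assay is 5, in the range 4.5 to 5.5.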

Compound 3, partition coefficient: 5.3
Compound 3: middle estimate off by 0.30 log units, on the low side, and the stated range covers the measured number.
By their numbers in this assay, from the lowest: compounds 1 and 3 (each within the scatter of the next); then compound 2.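

The change at this position is larger than a swap of one substituent: it removes the ether link and the distal substituent together, and phenyl in place of 4-(trifluoromethyl)phenoxy gives a number 0.90 log units lower from compound 2 to compound 3 (beyond the scatter) in this assay. Phenyl in place of 4-fluorophenoxy gives no change at the digits printed from compound 1 to compound 3 (within the scatter) on the same read-out, so the direct phenyl and the 4-fluorophenoxy group are not separated here, and compound 2 alone stands apart among the three. Nothing measured on these compounds offers a reason for either step.

As far as these compounds go, how much of the step from compound 2 belongs to the trifluoromethyl and how much to the ether oxygen remains open, and a 4-(trifluoromethyl)phenyl group would separate the two. From the compounds shown here alone, the reach of the position is also open for a distal ring carrying an amine or a carboxylic acid.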